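Toxicity to Vero Cells After a Sulfonyl Group Change

The source may report more compounds than this note shows. Statements on the series, on what has been measured and on what is new or still open speak of the compounds shown alone.

In an ADME assay on Vero cells (Chlorocebus sabaeus) for cytotoxicity, read by fluorescence and resazurin assay, with a stated time of 3 days (on this read-out higher numbers stand for lower toxicity in this test and lower numbers for higher toxicity in this test), compound 1 (`O=C(CCCc1cn(S(=O)(=O)c2cccc3ccccc23)c2ccccc12)NC1CCCCCC1`) gives > 250000 nM, which is a limit of the assay and not a number. Compound 2 (`O=C(CCCc1cn(S(=O)(=O)c2ccccc2)c2ccccc12)NC1CCCCCC1`) has no single number to stand on, its result being "not determined" (no result reported). Compound 3 (`Cc1cc(S(=O)(=O)n2cc(CCCC(=O)NC3CCCCCC3)c3ccccc32)c(C)cc1Cl`) has yet to be measured. The change 4-chloro-2,5-dimethylphenyl in place of phenyl on a sulfonyl sulfur places 4-chloro-2,5-dimethylphenyl in place of phenyl on a sulfonyl sulfur. Going by the values given here, no measured step shows what this change does in this assay, so no shift beyond the usual scatter is expected, the only guide being compound 1, with the limit of > 250000 nM in this assay, at which 1 of the 2 values shown sits. For compound 3, the estimated value is 200000 nM, with an expected range of 70000 nM to 250000 nM.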

Compound 3, half-maximal cytotoxic concentration: > 250000 nM
Compound 3 ended at the assay's limit (the forecaster's own chance of this, stated with the estimate: 60%); at least 1.2-fold (0.09 log units) between middle value and limit.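

No step can be read between compound 1 and compound 3, since each stands at a limit of the assay and not at a number: the limit of > 250000 nM in this assay, at which 2 of the 3 values shown sit.

The compounds shown leave open what changing the group on the sulfonyl sulfur does to toxicity in these cells, and where compound 2 stands.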